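A few compounds are considered here, and "the series" means these few. Any claim that something is new, unique, unknown or untested is made for them only; others in the source may bear on it.

Measured so far:
compound 1, `COc1ccc(C2=NN(c3ccccc3)C(c3ccc(C)cc3)C2S(=O)(=O)CC2=NCCO2)cc1` — 64.3%
compound 2, `COc1ccc(C2=NN(c3ccccc3)C(c3ccc(C)cc3)C2S(=O)(=O)CC2=NCCS2)cc1` — 43.9%
compound 3, `O=S(=O)(CC1=NCCS1)c1c(-c2ccccc2)noc1-c1ccccc1` — "not active" (no number reported)

Of the compounds shown here, three have been tested in a functional assay, tested at 75 ug/mL; on this read-out higher numbers stand for a stronger effect at the one concentration tested and lower numbers for a weaker effect. Compound 1 gives 64.3%, and compound 2 gives 43.9%. These two share one core and differ in a single place: a group of 5 heavy atoms (3 carbon, 1 nitrogen, 1 oxygen; one five-membered non-aromatic ring with 2 hetero atoms) in place of a group of 5 heavy atoms (3 carbon, 1 nitrogen, 1 sulfur; one five-membered non-aromatic ring with 2 hetero atoms), on a saturated chain carbon bound to a sulfonyl sulfur. That change made a step of a number 20.4 percentage points higher from compound 2 to compound 1 (beyond the scatter). Compound 3 is built on a different core, and the difference between the two cores is not broken down here. In this assay compound 3 is reported as "not active" (no number reported), without a number.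

Compound 4, `O=S(=O)(CC1=NCCO1)c1c(-c2ccccc2)noc1-c1ccccc1`, has not yet been measured. It differs from compound 3 by the same change that turns compound 2 into compound 1: a group of 5 heavy atoms (3 carbon, 1 nitrogen, 1 oxygen; one five-membered non-aromatic ring with 2 hetero atoms) in place of a group of 5 heavy atoms (3 carbon, 1 nitrogen, 1 sulfur; one five-membered non-aromatic ring with 2 hetero atoms), on a saturated chain carbon bound to a sulfonyl sulfur. The earlier step, a number 20.4 percentage points higher from compound 2 to compound 1 (beyond the scatter), is modest, and it was seen on one core only. Since compound 3 itself shows no activity, a step of that size would leave compound 4 weak at best, and the change may again produce no measurable number. The expected value for compound 4 is therefore 15%, between 0% and 40%.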

Compound 4, a percentage reported as activity, at one concentration (the size of the read-out at that concentration, not a potency): 58.1%
Beside the measured number, compound 4's estimate is 43.1 percentage points below it; measured number above the stated range.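

For the compounds shown here, compound 3 is reported as not active, without a number, so no step to compound 4 can be read, even though compound 4 gives 58.1% in this read-out. The compounds shown leave open how large the change from the sulfur-containing ring to the oxygen-containing ring is on this core. Nothing measured here offers a reason for this result.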